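The compounds below may be only part of what the source reports. "The series", "measured", "known", "first", "only" and "open" are said of these compounds alone.

Measured so far in an ADME assay on microsomes from liver (Rattus norvegicus) for metabolic stability, read by LC-MS; a higher number here means faster removal of the compound, a lower number slower removal:
compound 1 `COc1cc(N2CCN(C(=O)Cn3cnc4ccccc43)CC2)ccc1-c1cnc(C)o1` gives 22 mL.min-1.g-1
compound 3 `COc1cc(N2CCN(C(=O)CN3Cc4ccccc4C3)CC2)ccc1-c1cnc(C)o1` gives 42 mL.min-1.g-1
compound 2 `COc1cc(N2CCN(C(=O)N[C@@H](C)c3cccc4ccccc34)C[C@@H]2C)ccc1-c1cnc(C)o1` gives 150 mL.min-1.g-1

Of these three, compound 2 has the highest number; its gaps to compound 3 and to compound 1 both lie beyond the scatter, so compound 2 is the one removed fastest in this assay.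

Going by the values given here, only one measured pair differs in a single place: a 1.9-fold higher number from compound 1 to compound 3 (0.28 log units; within the scatter). That change sits on the saturated chain carbon bound to the carbonyl carbon, on the amide side of the shared core, and it stays within the scatter.

Compound 4 `COc1cc(N2CCN(C(=O)N[C@@H](C)c3cccc4ccccc34)CC2)ccc1-c1cnc(C)o1` differs from compound 2 at another place: hydrogen in place of methyl on a saturated ring carbon. Among the compounds with values here, no measured pair shows what removing that methyl does, and the one step that is known concerns a different part of the molecule and was itself within the scatter. The data therefore give no direction for the change, and the expectation for compound 4 is set near the value of compound 2, with a wide range that allows a step either way.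

In this assay compound 4 is expected to give 110 mL.min-1.g-1, with a likely range from 50 mL.min-1.g-1 to 250 mL.min-1.g-1. This estimate corresponds to an expected step of a 1.4-fold lower number from compound 2 to compound 4 (0.13 log units; within the scatter).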

Compound 4, intrinsic clearance in microsomes: 130 mL.min-1.g-1
The estimate for compound 4 lay 1.2-fold (0.07 log units) below the measured number, and the stated range covers the measured number.
By their numbers in this assay, from the lowest: compounds 1 and 3 (each within the scatter of the next); then compounds 4 and 2 (each within the scatter of the next).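

In this assay, hydrogen in place of methyl on this saturated ring carbon, next to the ring nitrogen, gives a 1.2-fold lower number from compound 2 to compound 4 (0.06 log units; within the scatter) and so leaves the number in the same place within the scatter. Without the methyl, compound 4 differs from compound 1 only in the part bound to the carbonyl carbon, and here compound 4 gives 130 mL.min-1.g-1 and compound 1 gives 22 mL.min-1.g-1, so the two numbers stand well apart even with this methyl absent. Nothing measured alongside these compounds explains why this ring carbon tolerates the change so quietly.

The compounds shown carry only methyl or hydrogen at this ring carbon, so what an ethyl group, a hydroxyl group or a fluorine atom would do there remains open. Going by these compounds alone, also open is whether the methyl would make as little difference when the part bound to the carbonyl carbon is the one found in compound 1 or in compound 3.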